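Swapping chloro for methoxy on a second core

A few compounds are considered here, and "the series" means these few. Any claim that something is new, unique, unknown or untested is made for them only; others in the source may bear on it.

Measured so far, in a functional assay on A549 cells (Homo sapiens) for antiproliferative activity, read by MTT assay, with a stated time of 72 h; a higher number here means a weaker inhibitor, a lower number a stronger inhibitor:
compound 1 `COc1ccc(OCCCON2C(N)=NC(N)=NC23CCOCC3)cc1` gives 660 nM
compound 2 `NC1=NC2(CCOCC2)N(OCCCOc2ccc(Cl)cc2)C(N)=N1` gives 360 nM
compound 3 `NC1=NC2(CCSCC2)N(OCCCOc2ccc(Cl)cc2)C(N)=N1` gives 580 nM

Compounds 2 and 3 share the same side chain but carry different cores; the difference between the two cores is not broken down here. Compound 4 `COc1ccc(OCCCON2C(N)=NC(N)=NC23CCSCC3)cc1` is not yet measured. It differs from compound 3 by one change: methoxy in place of chloro on an aromatic carbon. The same change is seen once already, from compound 2 to compound 1: methoxy in place of chloro on an aromatic carbon. That step gave a 1.8-fold higher number from compound 2 to compound 1 (0.26 log units; within the scatter) in this assay. Because the earlier step of a 1.8-fold higher number from compound 2 to compound 1 (0.26 log units; within the scatter) was small, the step from compound 3 to compound 4 is expected to be of similar size, estimated at a 1.7-fold higher number from compound 3 to compound 4 (0.24 log units; within the scatter). For compound 4 the expected value in this assay is 1000 nM, with a likely range from 500 nM to 2200 nM.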

Compound 4, half-maximal inhibitory concentration: 240 nM
For compound 4 the middle estimate is 4.2-fold (0.62 log units) above the measured one; measured number outside the range, below it.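

In this assay, putting methoxy in place of chloro on the second core gives a 2.4-fold lower number from compound 3 to compound 4 (0.38 log units; beyond the scatter). Set beside the same change on the first core, this step does not match: the same change on two cores in this assay, a 1.8-fold higher number (0.26 log units; within the scatter) from compound 2 to compound 1 and a 2.4-fold lower number (0.38 log units; beyond the scatter) from compound 3 to compound 4, 4.4-fold (0.65 log units) apart, beyond the scatter of two such steps. So in this series, the size and direction of this change on one core could not be carried over to the other, but two pairs of compounds cannot explain why the cores differ or give a rule for any further core.

The compounds shown leave open whether an amine or a carboxylic acid on the same aromatic carbon would also behave differently on the two cores. They also leave open what a longer chain would do on either core.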